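A few compounds are considered here, and "the series" means these few. Any claim that something is new, unique, unknown or untested is made for them only; others in the source may bear on it.

Compound 1 `CC[C@H]1OC(=O)[C@H](C)[C@@H](O[C@H]2C[C@@](C)(OC)[C@@H](O)[C@H](C)O2)[C@H](C)[C@@H](O[C@@H]2O[C@H](C)C[C@H](N(C)C)[C@H]2O)[C@](C)(O)C[C@@H](C)CN(C)[C@H](C)[C@@H](OCCCNC(=O)COC)[C@]1(C)O` is the most polar of the three measured compounds: in a physicochemical assay for lipophilicity, read by HPLC, measured as chromatographic lipophilicity, at pH 7.4 (a higher number here means a more lipophilic compound, a lower number a more polar compound), compound 1 gives 2.58, the lowest of the three numbers. Compound 3 `CCCCCCCC(=O)NCCCN(C)[C@H]1C[C@@H](C)O[C@@H](O[C@@H]2[C@@H](C)[C@H](O[C@H]3C[C@@](C)(OC)[C@@H](O)[C@H](C)O3)[C@@H](C)C(=O)O[C@H](CC)[C@@](C)(O)[C@H](O)[C@@H](C)N(C)C[C@H](C)C[C@@]2(C)O)[C@@H]1O` gives 3.74 in this assay, and compound 2 `CCCCCCCC(=O)NCCCO[C@H]1[C@H](C)O[C@@H](O[C@H]2[C@H](C)[C@@H](O[C@@H]3O[C@H](C)C[C@H](N(C)C)[C@H]3O)[C@](C)(O)C[C@@H](C)CN(C)[C@H](C)[C@@H](O)[C@](C)(O)[C@@H](CC)OC(=O)[C@@H]2C)C[C@@]1(C)OC` gives 4.1, both beyond the scatter above compound 1. Compound 4 `CCCCCCCC(=O)NCCCO[C@@H]1[C@@H](C)N(C)C[C@H](C)C[C@@](C)(O)[C@H](O[C@@H]2O[C@H](C)C[C@H](N(C)C)[C@H]2O)[C@@H](C)[C@H](O[C@H]2C[C@@](C)(OC)[C@@H](O)[C@H](C)O2)[C@@H](C)C(=O)O[C@H](CC)[C@@]1(C)O` differs from compound 1 by hexyl in place of methoxy on a saturated chain carbon bound to a carbonyl carbon. Going by the values given here, no measured pair shows this change alone, so the step is estimated from the heptylcarbonylamino compounds: a rise of a number 1.42 log units higher from compound 1 to compound 4 (beyond the scatter) is expected, well beyond the scatter, because compound 2 stands at 4.1. Compound 4 is therefore estimated at 4, between 3.5 and 4.5.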

Compound 4, distribution coefficient: 5.18
Estimate against measurement, compound 4: 1.18 log units below; the whole stated range lies below it.
By their numbers in this assay, from the lowest: compound 1; then compound 3; then compound 2; then compound 4.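

In this assay, hexyl in place of methoxy on a saturated chain carbon bound to a carbonyl carbon gives a large step, a number 2.60 log units higher from compound 1 to compound 4 (beyond the scatter). This is the first step among these compounds that can be read as a single change, and it shows that this position responds strongly to this exchange in this assay.

As far as these compounds go, whether a longer chain, a shorter chain or an amine in place of hexyl would give a step of similar size remains open. Nothing available here accounts for the size of this step.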